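The source may hold more compounds than are shown below. What is called first, only, known or untested is meant among the compounds shown, and "the series" means these compounds.

Working notes on the boronic-acid series in a functional assay on SK-OV-3 cells (Homo sapiens) for antiproliferative activity, read by MTT assay, with a stated time of 72 h; on this read-out lower numbers stand for stronger inhibition and higher numbers for weaker inhibition. Compound 1, `O=C(CCc1cccc2c1B(O)OC2)Nc1cccc(-c2cccc(Cl)c2)c1`, gives 300 nM in this assay. Compound 2, `COc1ccc(-c2cccc(NC(=O)CCc3cccc4c3B(O)OC4)c2)cc1`, gives 48 nM in this assay. Among the measured compounds shown here, the single step measured so far, 4-methoxyphenyl in place of 3-chlorophenyl on an aromatic carbon, is a 6.3-fold lower number from compound 1 to compound 2 (0.80 log units; beyond the scatter). For the measured compounds named here, on the two numbers available compound 2 therefore stands lowest, with compound 1 as its only neighbour.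

The next compound, compound 3, is `CC(=O)c1cccc(-c2cccc(NC(=O)CCc3cccc4c3B(O)OC4)c2)c1`. Its difference from compound 2 is 3-acetylphenyl in place of 4-methoxyphenyl on an aromatic carbon. Going by the values given here, the only measured step that bears on this change is the one from compound 1 to compound 2, since it also swaps the substituent on the pendant phenyl ring, and it was modest in size. Among the compounds with values here, no measured step tells whether 3-acetylphenyl behaves like 4-methoxyphenyl or like 3-chlorophenyl, so the direction is open. The working expectation is a step of about a 1.9-fold higher number from compound 2 to compound 3 (0.27 log units; within the scatter) for compound 3, not clearly beyond the scatter. Compound 3 is estimated at 90 nM in this assay, with a range from 30 nM to 300 nM.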

Compound 3, half-maximal inhibitory concentration: 68 nM
Compound 3: middle estimate off by 1.3-fold (0.12 log units), on the high side; measured number inside the range.
By their numbers in this assay, from the lowest: compounds 2 and 3 (each within the scatter of the next); then compound 1.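

In this assay, the pendant ring tolerates two quite different groups without a separable change, with 3-acetylphenyl in place of 4-methoxyphenyl giving a 1.4-fold higher number from compound 2 to compound 3 (0.15 log units; within the scatter), so the advantage over the 3-chlorophenyl group does not belong to 4-methoxyphenyl alone. The new comparison also isolates the substituent, since 3-chlorophenyl and 3-acetylphenyl differ only in the group carried by the ring, and acetyl in place of chloro gives a 4.4-fold lower number from compound 1 to compound 3 (0.64 log units; beyond the scatter), which shows that a group at this ring position can be compatible with a low number and that the chloro-bearing ring is the one that stands apart among the three compounds. No measurement bears on what underlies either step.

On these data alone, three groups cannot define a trend, and it remains open whether a hydroxyl, an amine or a carboxylic acid on the pendant ring would stay with compound 2 and compound 3 or fall with compound 1. Also open, as far as these compounds go, is whether an unsubstituted phenyl ring would match them, and whether a 4-acetylphenyl or a 3-methoxyphenyl group would give the same numbers as its isomer.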